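This account rests on a few compounds, and the source may have more. Where it says the series, first, only, none or still open, it means among the compounds named here.

Compound 1 `COCC(=N)NCCCCN` in an assay for inhibition of arginase-1 (Bos taurus), with a stated time of 30 min, tested at 1 mM (on this read-out lower numbers stand for less inhibition and higher numbers for more inhibition at the one concentration tested (going by the name of the read-out)), gives 21%; compound 2 `COCCC(=N)NCCCCN` gives 22%; compound 3 `COCCCC(=N)NCCC[C@H](N)C(=O)O` gives 20%. Going by the values given here, the single step between measured neighbours, a number 1 percentage points higher from compound 1 to compound 2 (within the scatter), lies within the scatter, and the three values sit within the scatter of one another, so no compound can be ranked against another. Compound 4 `COCCCC(=N)NCCCCN` awaits measurement. Against compound 3 the change is hydrogen in place of carboxy on a saturated chain carbon bound to an amine nitrogen and a saturated chain carbon. Among the compounds with values here, no measured pair covers this change. Compound 4 also differs from compound 2 by methoxymethyl in place of methoxy, a change that from compound 1 to compound 2 gave a number 1 percentage points higher from compound 1 to compound 2 (within the scatter), within the scatter. The step expected, a number 2 percentage points higher from compound 3 to compound 4 (within the scatter), is therefore none beyond the scatter. Compound 4 is estimated at 22%, with a range from 8% to 36%.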

Compound 4, a percentage reported as inhibition, at one concentration (the size of the read-out at that concentration, not a potency): 14%
The estimate for compound 4 lay 8 percentage points above the measured number, within the range that was stated.
By their numbers in this assay, from the lowest: compounds 4, 3, 1 and 2 (each within the scatter of the next).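

In this assay, going by these compounds alone, the first reading for hydrogen in place of carboxy at this saturated chain carbon is a number 6 percentage points lower from compound 3 to compound 4 (within the scatter) and so leaves the two compounds unranked. The chain changes read the same way, with methoxymethyl in place of methoxy giving a number 8 percentage points lower from compound 2 to compound 4 (within the scatter) and 2-methoxyethyl in place of methoxy giving a number 7 percentage points lower from compound 1 to compound 4 (within the scatter) so that neither separates the compounds. No supporting evidence bears on these readings. Still open, going by these compounds, is whether a hydroxy group in place of methoxy, or a longer chain, would give a number in this assay beyond the scatter.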